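The source may hold more compounds than are shown below. What is called first, only, known or untested is meant among the compounds shown, and "the series" means these compounds.

Measured so far in a functional assay on Hep 3B2 cells (Homo sapiens) for antiproliferative activity, read by MTT assay, with a stated time of 24 h, tested at 11.11 ug/mL; a lower number here means a weaker effect, a higher number a stronger effect of the compound at the concentration tested:
- compound 1 `CCc1ccc2nc(C(=O)Nc3c(F)cc(-c4cccc(F)c4)cc3F)c(C)c(O)c2c1` gives 46.3%
- compound 2 `CCOc1ccc2nc(C(=O)Nc3c(F)cc(-c4cccc(F)c4)cc3F)c(C)c(O)c2c1` gives 2.03%

Compound 2 stands lowest of the two numbers, below compound 1 by a number 44.3 percentage points lower from compound 1 to compound 2 (beyond the scatter). Compound 3 `Cc1c(C(=O)Nc2c(F)cc(-c3cccc(F)c3)cc2F)nc2ccc(OC(F)(F)F)cc2c1O` differs from compound 2 by trifluoromethyl in place of ethyl on an oxygen on an aromatic ring. Among the compounds with values here, only one measured step exists, the swap from ethyl to ethoxy, and it was large; no step varies the group on the oxygen itself, so it bears on this change only indirectly. Compound 3 is therefore expected to stay near compound 2, with no step beyond the scatter, at 10% (range 0% to 35%), a step of a number 8 percentage points higher from compound 2 to compound 3 (within the scatter).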

Compound 3, a percentage reported as inhibition, at one concentration (the size of the read-out at that concentration, not a potency): 37.9%
The estimate for compound 3 lay 27.9 percentage points below the measured number; the measured number lies above the stated range.
By their numbers in this assay, from the lowest: compound 2; then compounds 3 and 1 (each within the scatter of the next).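

In this assay the group on the oxygen matters at this position: trifluoromethyl in place of ethyl gives a number 35.9 percentage points higher from compound 2 to compound 3 (beyond the scatter), so an oxygen on the aromatic carbon does not by itself bring the low number of compound 2. Set against the ethyl of compound 1, trifluoromethoxy gives a number 8.4 percentage points lower from compound 1 to compound 3 (within the scatter), which leaves these two compounds indistinguishable here. No measurement at hand accounts for the difference between ethoxy and trifluoromethoxy.

Open, on these data alone, is whether the low number belongs to ethoxy alone or extends to methoxy or a longer alkoxy chain. An amine or a carboxylic acid on the same aromatic carbon also remains to be placed against these compounds.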